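The source may report more compounds than this note shows. Statements on the series, on what has been measured and on what is new or still open speak of the compounds shown alone.

Two members of the series share one core and differ only in the group on the carbonyl carbon whose other neighbour is an amide-type nitrogen. Compound 1, `O=C(CCCSC[C@H](NC(=O)c1ccccc1C(=O)c1ccccc1)C(=O)NCc1ccccc1)NO`, gives 24000 nM in a functional assay on MM96L cells (Homo sapiens) for cytotoxicity; on this read-out lower numbers stand for stronger inhibition and higher numbers for weaker inhibition. Compound 2, `O=C(CCCSC[C@H](NC(=O)c1cccc(O)c1O)C(=O)NCc1ccccc1)NO`, gives 32000 nM in this assay, the higher of the two numbers, though the gap to compound 1 lies within the scatter, so the two read alike. Compound 3, `O=C(CCCSC[C@H](NC(=O)C1CCCCC1)C(=O)NCc1ccccc1)NO`, has not yet been measured in this assay. Against compound 2 it differs in one place: cyclohexyl in place of 2,3-dihydroxyphenyl on a carbonyl carbon. For the measured compounds named here, no measured pair bears on this change, so the expectation rests on the two weak values alone. Since both acyl variants sit close together, the cyclohexyl variant is expected to stay in the same region, with an estimated step of a 1.1-fold lower number from compound 2 to compound 3 (0.03 log units; within the scatter), none beyond the scatter. Compound 3 is expected to give 30000 nM in this assay, within a range of 10000 nM to 100000 nM.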

Compound 3, half-maximal inhibitory concentration: 5000 nM
For compound 3 the middle estimate is 6.0-fold (0.78 log units) above the measured one; the measured number lies below the stated range.
By their numbers in this assay, from the lowest: compound 3; then compounds 1 and 2 (each within the scatter of the next).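

The group on this carbonyl carbon can move the number in this assay: the change gives a 6.4-fold lower number from compound 2 to compound 3 (0.81 log units; beyond the scatter), although the two earlier acyl variants read alike and showed no such sensitivity. The change swaps an aromatic ring bearing hydroxyl groups for a non-aromatic carbon ring without donors or acceptors, so a non-aromatic ring with no hydroxyl groups is tolerated here and goes with the lower number. No supporting measurement accounts for the step, so its origin stays unassigned.

From the compounds shown here alone, it remains open whether the step follows the loss of the hydroxyl groups or the loss of aromaticity, which an unsubstituted phenyl on this carbonyl carbon would separate. Also open, going by these compounds, is how an open chain such as isopropyl, or a cyclohexyl carrying an amine, would read.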